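The source may hold more compounds than are shown below. What is called first, only, known or untested is meant among the compounds shown, and "the series" means these compounds.

Three compounds have been measured in an ADME assay on microsomes from liver (Homo sapiens) for metabolic stability (a lower number here means that the compound disappears faster, a higher number that the compound lasts longer), so far:

Compound 1 `O=C1NC(=O)/C(=C/C(c2ccc(-c3ccc4cccc(F)c4c3)[nH]c2=O)C2CCCCC2)O1` gives 1.09 h
Compound 2 `O=C1NC(=O)/C(=C/C(c2ccc(-c3ccc4cccc(F)c4c3)[nH]c2=O)C2CC2)O1` gives 1.98 h
Compound 3 `O=C1NC(=O)/C(=C/C(c2ccc(-c3ccc4cccc(F)c4c3)[nH]c2=O)C2CCCC2)O1` gives 1.21 h

Compound 3 at 1.21 h lies within the scatter of both other compounds, so the three values set no order. Compound 4 `O=C1NC(=O)/C(=C/C(c2ccccc2)c2ccc(-c3ccc4cccc(F)c4c3)[nH]c2=O)O1` keeps the shared core and exchanges one group (phenyl in place of cyclopentyl on a saturated chain carbon bound to an aromatic carbon and a double-bonded chain carbon), with phenyl in place of cyclopentyl on a saturated chain carbon bound to an aromatic carbon and a double-bonded chain carbon. Three measured steps at that place bear on it (a 1.1-fold higher number from compound 1 to compound 3 (0.05 log units; within the scatter); a 1.6-fold lower number from compound 2 to compound 3 (0.21 log units; within the scatter); a 1.8-fold higher number from compound 1 to compound 2 (0.26 log units; within the scatter)), and each lies within the scatter. All three exchange one non-aromatic ring for another. For the measured compounds named here, no measured compound has an aromatic ring there, so the data do not cover this change directly. In this assay no step beyond the scatter is therefore expected, and the estimated step is small (a 1.1-fold higher number from compound 3 to compound 4 (0.03 log units; within the scatter)). Compound 4 is expected at 1.3 h with a range from 0.6 h to 2.6 h as the upper end.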

Compound 4, half-life: 2.1 h
The estimate for compound 4 lay 1.6-fold (0.21 log units) below the measured number; measured number inside the range.
By their numbers in this assay, from the lowest: compounds 1, 3, 2 and 4 (each within the scatter of the next).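

Compound 4 brings the first aromatic ring to the saturated chain carbon bound to an aromatic carbon and a double-bonded chain carbon, and in this assay the exchange gives a 1.7-fold higher number from compound 3 to compound 4 (0.24 log units; within the scatter), while the other two comparisons give a 1.1-fold higher number from compound 2 to compound 4 (0.03 log units; within the scatter) and a 1.9-fold higher number from compound 1 to compound 4 (0.28 log units; within the scatter), all within the scatter. The reach of the flat result at this place therefore widens: phenyl joins cyclopropyl, cyclopentyl and cyclohexyl, and no step among these four groups leaves the scatter. Nothing at hand offers an explanation for these values.

As far as these compounds go, it remains open whether a group that is not a carbon ring, such as an amine, a carboxylic acid or a longer chain, would give a step beyond the scatter at this place. Also open, from the compounds shown here alone, is whether a pyridine ring or a phenyl carrying a fluorine would stay within it.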